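The source may hold more compounds than are shown below. What is called first, only, known or untested is meant among the compounds shown, and "the series" means these compounds.

Of the compounds shown here, three that share one core have been tested in a functional assay on A375-C5 cells (Homo sapiens) for inhibition, read by sulforhodamine B assay, with a stated time of 48 h; a higher number here means a weaker inhibitor of growth, a lower number a stronger inhibitor of growth. Compound 1 `COC(=O)c1sc2cc(C#Cc3cccc(N)c3)cnc2c1N` gives 11600 nM in this assay, and compound 3 `COC(=O)c1sc2cc(C#Cc3ccc(N(C)C)cc3)cnc2c1N` gives 17700 nM; these two values lie within the usual scatter of each other. Compound 2 `COC(=O)c1sc2cc(C#Cc3ccccc3F)cnc2c1N` is reported only as a limit of the assay, > 150000 nM, so no number is known for it. On the numbers shown, compound 2 thus sits at the limit of > 150000 nM in this assay, at which 1 of the 3 values shown sits. Among the compounds with values here, the one measured step that bears on its place is an at least 12-fold higher number from compound 1 to compound 2 (1.11 log units; beyond the scatter), a large step towards weaker growth inhibition. Compound 4 `COC(=O)c1sc2cc(C#Cc3ccccc3N)cnc2c1N` has not yet been measured. It differs from compound 2 by amino in place of fluoro on an aromatic carbon. This change undoes the kind of swap seen in the step from compound 1 to compound 2, though at a different place on the ring, so a move back towards stronger growth inhibition is expected, of a size that is uncertain. The step is expected to be an at least 4.2-fold lower number from compound 2 to compound 4 (0.63 log units; beyond the scatter). Compound 4 is therefore estimated at 35000 nM, within a range from 10000 nM to 150000 nM.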

Compound 4, concentration for 50% growth inhibition: 3100 nM
For compound 4 the middle estimate is 11-fold (1.05 log units) above the measured one; measured number outside the range, below it.
By their numbers in this assay, from the lowest: compound 4; then compounds 1 and 3 (each within the scatter of the next). At a limit, above all of these: compound 2.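

The step from compound 1 to compound 2 changed the group and its place on the ring together, so it could not separate the two. With the place now held fixed, ortho to a large group, amino in place of fluoro gives an at least 48-fold lower number from compound 2 to compound 4 (1.68 log units; beyond the scatter) in this assay, which shows that the group alone can carry a large change. From the compounds shown here alone, the true size of this step is unknown because compound 2 has no number, only a limit: the limit of > 150000 nM in this assay, at which 1 of the 4 values shown sits. With the amino group kept and only its place changed, 2-aminophenyl in place of 3-aminophenyl gives a 3.7-fold lower number from compound 1 to compound 4 (0.57 log units; beyond the scatter), so place also counts, through a modest step.

The compounds shown leave open how a hydroxyl or a methylamino group on that same aromatic carbon would compare with amino. Going by these compounds, an acetamide there remains equally open.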